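Notes on four compounds sharing one core

A few compounds are considered here, and "the series" means these few. Any claim that something is new, unique, unknown or untested is made for them only; others in the source may bear on it.

All values below come from a functional assay on the whole organism (strain albino) for inhibition, with Rattus norvegicus as the target, read by paw edema, with stated times of 30 min and 2 h, at a dose of 100 mg/kg by the oral route; on this read-out higher numbers stand for more inhibition at the one dose given (going by the name of the read-out) and lower numbers for less inhibition.

compound 1, `COc1ccc(C2=NNC(c3c(Cl)cccc3Cl)C2)cc1OC`: 49%
compound 2, `COc1ccc(C2=NNC(c3c(Cl)cccc3Cl)C2)cc1`: 58%
compound 3, `COc1ccc(C2=NN(C(=O)CO[N+](=O)[O-])C(c3c(Cl)cccc3Cl)C2)cc1OC`: 49%

Compounds 1 and 2 share a core and differ by hydrogen in place of methoxy on an aromatic carbon; the step recorded is a number 9 percentage points higher from compound 1 to compound 2 (within the scatter). Compound 3 carries a second core that differs from that of compound 1 by ((nitrooxy)methyl)carbonyl in place of hydrogen on an amine nitrogen in a ring, and the step recorded there is no change at the digits printed from compound 1 to compound 3 (within the scatter). Compound 3 thus stands level with compound 1 at the digits given, and both stand within the scatter of compound 2.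

Compound 4, `COc1ccc(C2=NN(C(=O)CO[N+](=O)[O-])C(c3c(Cl)cccc3Cl)C2)cc1`, is not yet measured. It differs from compound 3 by hydrogen in place of methoxy on an aromatic carbon, the same change that was made from compound 1 to compound 2, and the two places are described in the same words, so it is the same change on the second core. The only evidence for its size is the single measured step from compound 1 to compound 2, which stayed within the scatter, and the step from compound 1 to compound 3, which also stayed within the scatter; whether the second core behaves alike under this change is not shown by anything measured.

On that basis the step for compound 4 is expected to be a number 7 percentage points higher from compound 3 to compound 4 (within the scatter), small and within the scatter, because the matching step a number 9 percentage points higher from compound 1 to compound 2 (within the scatter) was small. Compound 4 is therefore estimated at 56% in this assay, with a range from 44% to 68%.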

Compound 4, a percentage reported as inhibition, in the whole organism at one dose (the size of the read-out at that dose, not a potency): 42%
Compound 4: middle estimate off by 14 percentage points, on the high side; the measured number lies below the stated range.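

In this assay, hydrogen in place of methoxy on an aromatic carbon gives a number 7 percentage points lower from compound 3 to compound 4 (within the scatter), and this does not match the same change on the core of compound 1: the same change on two cores in this assay, a number 9 percentage points higher (within the scatter) from compound 1 to compound 2 and a number 7 percentage points lower (within the scatter) from compound 3 to compound 4, 16 percentage points apart, beyond the scatter of two such steps Read the other way round, ((nitrooxy)methyl)carbonyl in place of hydrogen on the ring amine nitrogen gives a number 16 percentage points lower from compound 2 to compound 4 (beyond the scatter), which also fails to match its counterpart on the other core: the same change on two cores in this assay, no change at the digits printed (within the scatter) from compound 1 to compound 3 and a number 16 percentage points lower (beyond the scatter) from compound 2 to compound 4, 16 percentage points apart, beyond the scatter of two such steps Both comparisons rest on the same four compounds, so they are one observation seen from two sides: the two changes do not simply add up in this small set, but nothing here gives a reason for that, and it cannot be said whether it would hold for any other change in the series.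

From the compounds shown here alone, it remains open whether the same mismatch appears with other groups at that place on the aromatic ring, such as a hydroxyl or a fluorine in place of the methoxy. Going by these compounds, it is equally open how the result depends on the nitrooxy end of the side chain, which a plain acetyl, a carboxylic acid, an amine or a longer chain between the carbonyl and the nitrooxy group could help to separate.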